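The source may report more compounds than this note shows. Statements on the series, on what has been measured and on what is new or still open speak of the compounds shown alone.

In a functional assay on HepG2 cells (Homo sapiens) for inhibition, read by MTT assay, with a stated time of 72 h (on this read-out lower numbers stand for stronger inhibition and higher numbers for weaker inhibition), compound 1 `CC(C)(C)n1cc2c(n1)C(=O)CC1(CCN(C(=O)c3cc(-c4ccccc4)nc4ccccc34)CC1)O2` gives 2110 nM, and compound 2 `CC(C)(C)n1cc2c(n1)C(=O)CC1(CCN(C(=O)c3cc(-c4ccccn4)nc4ccccc34)CC1)O2` gives 1500 nM. Within the data shown here, compound 2 therefore stands level with compound 1, the only other compound measured, and the step between them is a 1.4-fold lower number from compound 1 to compound 2 (0.15 log units; within the scatter). That step puts pyridin-2-yl in place of phenyl on an aromatic carbon. Compound 3 `CC(C)(C)n1cc2c(n1)C(=O)CC1(CCN(C(=O)c3cc(Cl)nc4ccccc34)CC1)O2` keeps the shared core but carries chloro in place of pyridin-2-yl at that same carbon, next to the ring nitrogen: chloro in place of pyridin-2-yl on an aromatic carbon. Among the measured compounds shown here, only the one measured step bears on this change, and it bears only indirectly, since it exchanged one aromatic ring for another, whereas here the ring leaves altogether. For the measured compounds named here, no compound without a ring at this place has been measured, so the size of the step is poorly constrained. A modest move towards a higher number in this assay is the tentative expectation, and a step within the scatter would not surprise. The expected step is a 2.0-fold higher number from compound 2 to compound 3 (0.30 log units; within the scatter). For compound 3 the estimated value is 3000 nM, with an expected range from 1000 nM to 10000 nM.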

Compound 3, half-maximal inhibitory concentration: 4720 nM
Beside the measured number, compound 3's estimate is 1.6-fold (0.20 log units) below it, within the range that was stated.
By their numbers in this assay, from the lowest: compounds 2 and 1 (each within the scatter of the next); then compound 3.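

In this assay, the earlier pair had shown only that phenyl and pyridin-2-yl on this aromatic carbon, next to the ring nitrogen, stand within the scatter of each other, and chloro now gives the first change at this place that reads beyond it, with a 3.1-fold higher number from compound 2 to compound 3 (0.50 log units; beyond the scatter) and a 2.2-fold higher number from compound 1 to compound 3 (0.35 log units; beyond the scatter) as its two modest steps. Both steps point the same way, so among these three compounds either six-membered aromatic ring goes with a lower number than chloro, and the choice between ring and no ring counts for more here than the choice between the two rings. No supporting measurement bears on why the number moves at this carbon.

The compounds shown leave open whether a ring as such is what goes with the lower number or whether any group larger than chloro would do, a question that a methyl group, a morpholine or a piperidine at this carbon could help to settle. They also leave open how a plain hydrogen, or an amine or a carboxylic acid carried on the phenyl ring, would compare with the groups seen so far.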